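The source may report more compounds than this note shows. Statements on the series, on what has been measured and on what is new or still open speak of the compounds shown alone.

Measured so far:
compound 1, `Cc1cc(-c2ccc(Cl)cc2Cl)c(S(C)(=O)=O)cc1C(=O)N=C(N)N` — 42 nM
compound 2, `Cc1cc(Sc2cccc(Cl)c2)c(S(C)(=O)=O)cc1C(=O)N=C(N)N` — 37 nM

In a functional assay for inhibition of sodium/hydrogen exchanger (Oryctolagus cuniculus) (a lower number here means a stronger inhibitor, a higher number a weaker inhibitor), compound 1 gives 42 nM. Among the compounds with values here, compound 2 gives 37 nM, the lowest of the two numbers so far, although the step of a 1.1-fold lower number from compound 1 to compound 2 (0.06 log units; within the scatter) leaves the two compounds indistinguishable within the usual scatter. Compound 2 thus stands level with compound 1 on the numbers shown.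

Compound 3, `Cc1cc(N2CCCC2)c(S(C)(=O)=O)cc1C(=O)N=C(N)N`, is not yet measured in this assay. Its difference from compound 2:
pyrrolidin-1-yl in place of (3-chlorophenyl)sulfanyl on an aromatic carbon

Within the data shown here, the single measured step, a 1.1-fold lower number from compound 1 to compound 2 (0.06 log units; within the scatter), exchanges one aromatic chlorinated substituent for another at the same place and says little about replacing the (3-chlorophenyl)sulfanyl group with pyrrolidin-1-yl, a smaller, non-aromatic, nitrogen-containing ring. Among the measured compounds shown here, no measured pair bears directly on this change. The estimate for compound 3 is therefore held near the values of compound 1 and compound 2, leaning towards a somewhat weaker inhibitor, with a broad range on both sides. The expected step is a 2.7-fold higher number from compound 2 to compound 3 (0.43 log units; beyond the scatter). Compound 3 is estimated at 100 nM, within 25 nM to 400 nM.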

Compound 3, half-maximal inhibitory concentration: 11 nM
Estimate against measurement, compound 3: 9.1-fold (0.96 log units) above; measured number below the stated range.
By their numbers in this assay, from the lowest: compound 3; then compounds 2 and 1 (each within the scatter of the next).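

In this assay, within the data shown here, the position ortho to a methylsulfonyl group and meta to a methyl group tolerates more than an aromatic substituent: pyrrolidin-1-yl in place of (3-chlorophenyl)sulfanyl gives a 3.4-fold lower number from compound 2 to compound 3 (0.53 log units; beyond the scatter), the first step beyond the scatter. The comparison with the 2,4-dichlorophenyl group runs the same way, with a 3.8-fold lower number from compound 1 to compound 3 (0.58 log units; beyond the scatter), so among these three compounds neither a chlorinated aromatic ring nor a sulfur link is required for the lowest number, and the smaller, non-aromatic ring gives a lower number than both. Nothing measured here accounts for this difference.

The three compounds leave open whether the step belongs to the pyrrolidine ring as such or to a nitrogen attached at this position; piperidin-1-yl, morpholin-4-yl or an open-chain dimethylamino group in the same place would separate these readings. Also open, as far as these compounds go, is how far the shared core carries this result, since the methyl group and the methylsulfonyl group stay unchanged throughout, and a compound with an ethyl group or a chlorine in place of that methyl group would test it.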